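The source may report more compounds than this note shows. Statements on the series, on what has been measured and on what is new or still open speak of the compounds shown alone.

Compound 1 `Cc1ccc(S(=O)(=O)c2cnc3c(F)cccc3c2-c2cccc(F)c2)cc1F` gives 3.92 mL/min in an ADME assay on microsomes from liver (Homo sapiens) for metabolic stability, tested at 2.5 uM; on this read-out higher numbers stand for fast clearance and lower numbers for slow clearance.
Compound 2 `COc1ccc(-c2c(S(=O)(=O)c3cc(F)cc(F)c3)cnc3c(F)cccc23)cc1` gives 2.59 mL/min in this assay.
Compound 3 `Cc1ccc(S(=O)(=O)c2cnc3c(F)cccc3c2-c2ccc(Cl)cc2)cc1F` gives 2.2 mL/min in this assay.

On these numbers compound 3 has the lowest of the three, yet its gaps to compound 2 and to compound 1 both lie within the scatter, so the three compounds cannot truly be separated on this read-out. Compound 4 `COc1ccc(-c2c(S(=O)(=O)c3ccc(C)c(F)c3)cnc3c(F)cccc23)cc1` has not yet been measured. It differs from compound 3 in one place: methoxy in place of chloro on an aromatic carbon. Cut one bond further out, the change reads 4-chlorophenyl to 4-methoxyphenyl. Among the compounds with values here, no measured step swaps chloro for methoxy. Within the data shown here, the only measured step, a 1.8-fold lower number from compound 1 to compound 3 (0.25 log units; within the scatter), altered the same aryl group in a different way and stayed within the scatter. Compound 2 also carries a 4-methoxyphenyl group, joined to a different sulfonyl partner, and its value sits close to that of compound 3. Taken together, the expectation is that a 1.1-fold higher number from compound 3 to compound 4 (0.06 log units; within the scatter) stays within the scatter. Compound 4 is therefore estimated at 2.5 mL/min, with a range from 1.3 mL/min to 4.8 mL/min.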

Compound 4, intrinsic clearance in a liver preparation (reported as CLH), per the amount of preparation that the assay uses: 3.27 mL/min
Compound 4: middle estimate off by 1.3-fold (0.12 log units), on the low side; measured number inside the range.
By their numbers in this assay, from the lowest: compounds 3, 2, 4 and 1 (each within the scatter of the next).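

At this position, the first direct test of methoxy in place of chloro gives a 1.5-fold higher number from compound 3 to compound 4 (0.17 log units; within the scatter) in this assay and so does not separate the two compounds, even though methoxy brings in a hydrogen-bond acceptor that chloro lacks. A larger change to the same aryl group, 4-methoxyphenyl in place of 3-fluorophenyl, gives a 1.2-fold lower number from compound 1 to compound 4 (0.08 log units; within the scatter) and also leaves the two compounds unseparated. Within the data shown here, changing the sulfonyl partner instead, with 3-fluoro-4-methylphenyl in place of 3,5-difluorophenyl, gives a 1.3-fold higher number from compound 2 to compound 4 (0.10 log units; within the scatter) and so shows that no step at either place has yet gone beyond the scatter.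

No measurement is available that explains these numbers. Still open, going by these compounds, is whether a different kind of group on this aromatic carbon, such as an amine or a carboxylic acid, would give a step beyond the scatter.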